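Halogen swap across the oxazole and thiazole pair

The source may hold more compounds than are shown below. What is called first, only, known or untested is meant among the compounds shown, and "the series" means these compounds.

Measured so far:
- compound 1, `Fc1ccc(-c2nnc(SCCCN3CCN(c4nc5ccccc5o4)CC3)o2)cc1`: 75700 nM
- compound 2, `Brc1ccc(-c2nnc(SCCCN3CCN(c4nc5ccccc5o4)CC3)o2)cc1`: 123000 nM
- compound 3, `Fc1ccc(-c2nnc(SCCCN3CCN(c4nc5ccccc5s4)CC3)o2)cc1`: 71700 nM

Three compounds have been run in a functional assay on A549 cells (Homo sapiens) for inhibition, read by MTT assay, with a stated time of 72 h; on this read-out lower numbers stand for stronger inhibition and higher numbers for weaker inhibition. Within the data shown here, all three numbers sit close together; no compound can be set above or below another on this read-out.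

The step from compound 1 to compound 2 is bromo in place of fluoro on an aromatic carbon. It gave a 1.6-fold higher number from compound 1 to compound 2 (0.21 log units; within the scatter). The step from compound 1 to compound 3 is 1,3-benzothiazol-2-yl in place of 1,3-benzoxazol-2-yl on an amine nitrogen in a ring, and it gave a 1.1-fold lower number from compound 1 to compound 3 (0.02 log units; within the scatter). Compound 3 and compound 2 share no single-point difference; their two values stand within the scatter of each other.

Compound 4, `Brc1ccc(-c2nnc(SCCCN3CCN(c4nc5ccccc5s4)CC3)o2)cc1`, has not yet been measured in this assay. It differs from compound 3 by bromo in place of fluoro on an aromatic carbon. The place reads word for word as it does for the change from compound 1 to compound 2, so this is the same change, now made on the core of compound 3 rather than on the core of compound 1. The earlier instance gave a 1.6-fold higher number from compound 1 to compound 2 (0.21 log units; within the scatter), a step within the scatter.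

Among the measured compounds shown here, for compound 4 the expected step is a 1.6-fold higher number from compound 3 to compound 4 (0.21 log units; within the scatter), resting on the single earlier instance of the same change and on the value of compound 3, 71700 nM. Compound 4 is estimated at 115000 nM, with a range from 55000 nM to 240000 nM, since one prior instance gives little basis for anything narrower.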

Compound 4, half-maximal inhibitory concentration: 62500 nM
Compound 4: middle estimate off by 1.8-fold (0.26 log units), on the high side; the range from low to high includes it.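

In this assay, bromo in place of fluoro on an aromatic carbon gave a 1.1-fold lower number from compound 3 to compound 4 (0.06 log units; within the scatter), and this step agrees with the earlier one on the core of compound 1: the same change on two cores in this assay, a 1.6-fold higher number (0.21 log units; within the scatter) from compound 1 to compound 2 and a 1.1-fold lower number (0.06 log units; within the scatter) from compound 3 to compound 4, 1.9-fold (0.27 log units) apart, within the scatter of two such steps. The exchange of 1,3-benzoxazol-2-yl for 1,3-benzothiazol-2-yl on an amine nitrogen in a ring gave a 2.0-fold lower number from compound 2 to compound 4 (0.29 log units; within the scatter), and this step likewise agrees with its earlier instance: the same change on two cores in this assay, a 1.1-fold lower number (0.02 log units; within the scatter) from compound 1 to compound 3 and a 2.0-fold lower number (0.29 log units; within the scatter) from compound 2 to compound 4, 1.9-fold (0.27 log units) apart, within the scatter of two such steps. Neither change therefore reads differently from one core to the other, but all four steps lie within the scatter, so these data show no effect of either change on either core and cannot show that a real effect carries over.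

The compounds shown leave open whether a group other than the two halogens on the phenyl ring, such as a methoxy group, a nitrile or an amine, would move the number beyond the scatter. As far as these compounds go, a longer chain on the shared core, and the behaviour of these four compounds in other cell lines, also remain open.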